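Replacing the dimethylphenyl ring with a chlorophenyl ring

A few compounds are considered here, and "the series" means these few. Any claim that something is new, unique, unknown or untested is made for them only; others in the source may bear on it.

Compound 1 `COc1cc(-c2cc(C(=O)/C=C/c3ccccc3)nc3cc(-c4ccccc4)nn23)cc(OC)c1OC`: 19200 nM
Compound 2 `COc1cc(-c2cc(/C=C/C(=O)c3ccc(C)c(C)c3)nc3cc(-c4ccccc4)nn23)cc(OC)c1OC`: 13500 nM

Among the compounds with values here, in a functional assay on MDA-MB-231 cells (Homo sapiens) for antiproliferative activity, read by MTT assay, with a stated time of 24 h (on this read-out lower numbers stand for stronger inhibition and higher numbers for weaker inhibition), compound 2 gives 13500 nM, the lowest of the two numbers so far. Within the data shown here, its only neighbour, compound 1, gives 19200 nM in this assay, and the change a 1.4-fold lower number from compound 1 to compound 2 (0.15 log units; within the scatter) lies within the scatter, so the two compounds cannot be told apart on this read-out.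

Compound 3 `COc1cc(-c2cc(/C=C/C(=O)c3ccc(Cl)cc3)nc3cc(-c4ccccc4)nn23)cc(OC)c1OC` differs from compound 2 in one place: 4-chlorophenyl in place of 3,4-dimethylphenyl on a carbonyl carbon. Among the measured compounds shown here, the single measured step altered both the direction of the unsaturated ketone and the substituents on the aryl ring, so it bears only loosely on this swap; still, that larger change moved the number hardly at all. A smaller exchange of one aryl ring for another is expected to produce no step beyond the scatter, that is a 1.0-fold higher number from compound 2 to compound 3 (0.02 log units; within the scatter) in this assay. Compound 3 is therefore estimated at 14000 nM, with a range from 6000 nM to 35000 nM.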

Compound 3, half-maximal inhibitory concentration: 32500 nM
Estimate against measurement, compound 3: 2.3-fold (0.37 log units) below; measured number inside the range.
By their numbers in this assay, from the lowest: compounds 2, 1 and 3 (each within the scatter of the next, the first and the last beyond it).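

In this assay, within the data shown here, exchanging one aryl ring for another on this carbonyl carbon gives the first step beyond the scatter, with a 2.4-fold higher number from compound 2 to compound 3 (0.38 log units; beyond the scatter) as a modest change, so 4-chlorophenyl and 3,4-dimethylphenyl are not interchangeable at this position. Compound 3 still cannot be told apart from the compound with the reversed unsaturated ketone and an unsubstituted phenyl ring, with a 1.7-fold higher number from compound 1 to compound 3 (0.23 log units; within the scatter) remaining inside the scatter. No supporting measurement is available to explain why the number rises with the 4-chlorophenyl ring.

The compounds shown leave open whether the step follows from removing the two methyl groups or from adding the chlorine, as both differences come together in this swap. A 4-methylphenyl ring could help separate the two, while a 4-aminophenyl ring on the same carbonyl carbon remains an open case.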